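A few compounds are considered here, and "the series" means these few. Any claim that something is new, unique, unknown or untested is made for them only; others in the source may bear on it.

Compound 1 `C=C1CC[C@@H]2[C@](C)(CO)[C@H](O)CC[C@@]2(C)[C@@H]1CCC1=CCOC1=O` has a side chain ending in a five-membered non-aromatic ring with one hetero atom. In a functional assay on NTUB1 cells (Homo sapiens) for cytotoxicity, read by MTT assay, with a stated time of 48 h (a lower number here means a stronger inhibitor, a higher number a weaker inhibitor), compound 1 gives only a limit, > 100000 nM, and not a number. Compound 2 `C=C1CC[C@@H]2[C@](C)(COC(=O)COc3ccccc3)[C@H](O)CC[C@@]2(C)[C@@H]1CCc1ccoc1` is built on the same core with a different side chain and a further substituent. In this assay compound 2 also returns only the limit, > 100000 nM. Compound 3 `C=C1CC[C@H]2[C@@](C)(CCC(=O)[C@@]2(C)CO)[C@@H]1CCc1ccoc1` is the one compound shown with a number: in this assay compound 3 gives 63100 nM, a weak inhibition. So compound 1 stands at the limit of > 100000 nM in this assay, at which 2 of the 3 values shown sit, and no pair of measured compounds differs in a single place, so no measured step can be counted.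

Compound 4 `C=C1CC[C@@H]2[C@](C)(CO)[C@H](O)CC[C@@]2(C)[C@@H]1CC(O)c1ccoc1` differs from compound 1 in one place: a group of 7 heavy atoms (5 carbon, 2 oxygen; one five-membered aromatic ring with 1 hetero atom) in place of a group of 7 heavy atoms (5 carbon, 2 oxygen; one five-membered non-aromatic ring with 1 hetero atom), on a saturated chain carbon bound to a saturated ring carbon. Among the compounds with values here, no measured pair shows the effect of this change directly. Within the data shown here, the only comparison available is that compound 3, which shares the aromatic five-membered ring with compound 4, gives a weak number, while compound 1 gives a limit. The step from compound 1 to compound 4 is therefore expected to be small, an at least 1.2-fold lower number from compound 1 to compound 4 (0.09 log units; that floor lies within the scatter), staying close to the limit. Compound 4 is estimated at 80000 nM, within a range of 30000 nM to 300000 nM.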

Compound 4, half-maximal inhibitory concentration: > 100000 nM
Compound 4 gave a limit, no number; the forecaster's own chance of this, stated with the estimate: 55%; middle value at least 1.2-fold (0.09 log units) away from the limit.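

In this assay compound 1 and compound 4 each return only a limit and not a number, so the step between them cannot be read. The compounds shown leave open whether placing (furan-3-yl)(hydroxy)methyl where the five-membered non-aromatic ring stood changes the inhibition at all, since most values sit at one limit: the limit of > 100000 nM in this assay, at which 3 of the 4 values shown sit.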